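Chloro to bromo swap and cell toxicity

The source may hold more compounds than are shown below. What is called first, only, known or untested is meant among the compounds shown, and "the series" means these compounds.

Measured so far, in an ADME assay on Vero cells (Chlorocebus sabaeus) for cytotoxicity, read by neutral red uptake, with a stated time of 72 h; on this read-out higher numbers stand for weaker inhibition and lower numbers for stronger inhibition:
compound 1 `Clc1ccc(Nc2ccnc(NCCCNc3ccnc4cc(Cl)ccc34)n2)cc1`: 13400 nM
compound 2 `Clc1ccc2c(NCCCNc3nccc(Nc4ccc(Br)cc4)n3)ccnc2c1`: 11200 nM
compound 3 `Clc1ccc(Nc2ccnc(NCCCCNc3ccnc4cc(Cl)ccc34)n2)cc1`: 11000 nM

Compound 1 and compound 2 differ by bromo in place of chloro on an aromatic carbon, and the step is a 1.2-fold lower number from compound 1 to compound 2 (0.08 log units; within the scatter). The values of compound 3, compound 2 and compound 1 all lie within the usual scatter of one another, so nothing separates the three. The difference between the core of compound 3 and the core of compound 1 is not broken down here. Compound 4 `Clc1ccc2c(NCCCCNc3nccc(Nc4ccc(Br)cc4)n3)ccnc2c1` is not yet measured; it differs from compound 3 by bromo in place of chloro on an aromatic carbon, the same change as between compound 1 and compound 2, at the same place. In this assay this same change is expected to give a step that resembles a 1.2-fold lower number from compound 1 to compound 2 (0.08 log units; within the scatter), that is, an estimated 1.2-fold lower number from compound 3 to compound 4 (0.06 log units; within the scatter). Compound 4 is therefore estimated at 9500 nM, expected to fall between 5000 nM and 20000 nM.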

Compound 4, half-maximal inhibitory concentration: 10000 nM
For compound 4 the middle estimate is 1.1-fold (0.02 log units) below the measured one; the range from low to high includes it.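

In this assay, 4-bromophenyl in place of 4-chlorophenyl gives a 1.1-fold lower number from compound 3 to compound 4 (0.04 log units; within the scatter). The steps on the two cores agree: the same change on two cores in this assay, a 1.2-fold lower number (0.08 log units; within the scatter) from compound 1 to compound 2 and a 1.1-fold lower number (0.04 log units; within the scatter) from compound 3 to compound 4, 1.1-fold (0.04 log units) apart, within the scatter of two such steps. For the compounds shown here, this shows only that the swap carries between these two cores without a step beyond the scatter; since both steps lie within the scatter, it does not show that bromo in place of chloro has any effect of its own on this read-out, nor that the agreement extends to other cores.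

Still open, on these data alone, is how other groups at this place compare, such as fluoro, methyl, trifluoromethyl or an amine. Also open, as far as these compounds go, is whether the same swap reads alike on a longer chain than that of compound 3 and compound 4.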